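A few compounds are considered here, and "the series" means these few. Any claim that something is new, unique, unknown or untested is made for them only; others in the source may bear on it.

Measured so far:
Compound 1 `C[C@]1(O)CC(=O)OC(CSc2nc(-c3ccccc3)c(-c3ccccc3)[nH]2)C1` gives 140 nM in an assay on microsomes from liver for inhibition of sterol O-acyltransferase 1 (Rattus norvegicus); on this read-out higher numbers stand for weaker inhibition and lower numbers for stronger inhibition.
Compound 2 `CO[C@H]1C[C@H](O)C[C@@H](CSc2nc(-c3ccccc3)c(-c3ccccc3)[nH]2)O1` gives 90 nM in this assay.

Going by the values given here, compound 2 has the lowest of the two numbers, but its only neighbour is compound 1, and the step of a 1.6-fold lower number from compound 1 to compound 2 (0.19 log units; within the scatter) lies within the scatter, so the two cannot be told apart on this read-out. Compound 3 `O=C1CCCC(CSc2nc(-c3ccccc3)c(-c3ccccc3)[nH]2)O1` is not yet measured. It differs from compound 2 in one place: a group of 7 heavy atoms (5 carbon, 2 oxygen; one six-membered non-aromatic ring with 1 hetero atom) in place of a group of 9 heavy atoms (6 carbon, 3 oxygen; one six-membered non-aromatic ring with 1 hetero atom), on a saturated chain carbon bound to a sulfur. The group that enters carries a double bond outside aromatic rings and no hydrogen-bond donor, while the group that leaves carries one donor and three defined stereocentres.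

Among the compounds with values here, only one measured step touches the same position, and that is a 1.6-fold lower number from compound 1 to compound 2 (0.19 log units; within the scatter), a swap of two rings of the same size and atom count that changed nothing beyond the scatter. Compound 1 already holds a ring of the kind that enters here, so the expectation for compound 3 is a number near those of compound 1 and compound 2, with the step of a 2.2-fold higher number from compound 2 to compound 3 (0.35 log units; beyond the scatter) estimated as a small weakening. Compound 3 is expected to give 200 nM, between 70 nM and 600 nM.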

Compound 3, half-maximal inhibitory concentration: 740 nM
Compound 3: the middle estimate sits 3.7-fold (0.57 log units) below what was measured; the measured number lies above the stated range.
By their numbers in this assay, from the lowest: compounds 2 and 1 (each within the scatter of the next); then compound 3.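

In this assay, the group on a saturated chain carbon bound to a sulfur turns out to matter: the swap of one ring for another at this place gave a difference within the scatter, but the smaller ring group of compound 3 gives an 8.2-fold higher number from compound 2 to compound 3 (0.91 log units; beyond the scatter) and, measured against the other ring group, a 5.3-fold higher number from compound 1 to compound 3 (0.72 log units; beyond the scatter), both beyond the scatter and both towards weaker inhibition. Compared with compound 2, the entering group has fewer heavy atoms, no hydrogen-bond donor, fewer hydrogen-bond acceptors, no defined stereocentres and a double bond outside aromatic rings, so this single swap alters several counted features at once and the step cannot be pinned on any one of them. Nothing available here accounts for the rise in the number.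

The compounds shown leave open which of these differences carries the step, since each of them changes together with the others in compound 3. They also leave open how an amine, a carboxylic acid or a longer chain at this same place would compare with the ring groups of compound 1 and compound 2.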